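Thiosemicarbazone Pair Assessed for Growth Inhibition in HeLa Cells

A few compounds are considered here, and "the series" means these few. Any claim that something is new, unique, unknown or untested is made for them only; others in the source may bear on it.

The account begins with compound 1 `COc1ccccc1NC(=S)N/N=C/c1ccc2ccccc2n1`, a thiosemicarbazone whose shared core is shown in its structure. In a functional assay on HeLa cells (Homo sapiens) for antiproliferative activity, read by sulforhodamine B assay, with a stated time of 72 h (on this read-out higher numbers stand for weaker inhibition and lower numbers for stronger inhibition), compound 1 gives > 100000 nM, which is a limit of the assay rather than a number. Compound 2 `NC(=S)N/N=C/c1cnc2ccccc2n1` carries the same kind of thiosemicarbazone arm on a different heteroaromatic ring. In this assay compound 2 gives > 100000 nM, again a limit and not a number. Taken together, both values shown sit at the limit of > 100000 nM in this assay, at which 2 of the 2 values shown sit, so compound 1 stands exactly where compound 2 stands, with no measurable inhibition recorded for either.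

The step under consideration leads to compound 3 `Fc1cccc(NC(=S)N/N=C/c2ccc3ccccc3n2)c1`. The change from compound 1 to compound 3 is 3-fluorophenyl in place of 2-methoxyphenyl on an amide-type nitrogen. Going by the values given here, no step between measured compounds is available for comparison, so the expectation rests on the position of compound 1 at the limit. Compound 3 is expected to remain at or near that limit, with a step of a number no higher from compound 1 to compound 3 (the limit leaves the size open) in this assay that is expected to be none beyond the scatter. The estimate for compound 3 is 100000 nM, with an expected range from 30000 nM to 300000 nM.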

Compound 3, half-maximal inhibitory concentration: 70100 nM
Compound 3: the middle estimate sits 1.4-fold (0.15 log units) above what was measured; low and high end bracket the measured number.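

With this change the account gains its first value that is a number and not a limit: in this assay compound 3 gives 70100 nM. Placing 3-fluorophenyl in place of 2-methoxyphenyl on the amide-type nitrogen gives an at least 1.4-fold lower number from compound 1 to compound 3 (0.15 log units; that floor lies within the scatter), so the values show that a change at this position can yield a readable number, although the floor of the step does not by itself establish a difference beyond the usual scatter. The true size of the step remains unknown because the starting value of compound 1 is only a limit: the limit of > 100000 nM in this assay, at which 2 of the 3 values shown sit.

The names 2-methoxyphenyl and 3-fluorophenyl differ in both the group carried on the phenyl ring and its numbered position, and this single step does not separate those two differences. The compounds shown also leave open how the same nitrogen would respond to an entirely different substituent, such as a dimethylamino-bearing phenyl, a carboxylic acid-bearing phenyl or a longer alkyl chain.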